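This account rests on a few compounds, and the source may have more. Where it says the series, first, only, none or still open, it means among the compounds named here.

Measured so far in a functional assay on MCF7 cells (Homo sapiens) for cytotoxicity, read by MTT assay, with a stated time of 72 h; a lower number here means a stronger inhibitor, a higher number a weaker inhibitor:
compound 1 `O=C(N/N=C/c1ccc(O)c(Br)c1)Nc1cc2c(Nc3ccc(F)c(Cl)c3)ncnc2cc1O[C@H]1CCOC1`: 2690 nM
compound 2 `O=C(N/N=C/c1ccc(O)cc1)Nc1cc2c(Nc3ccc(F)c(Cl)c3)ncnc2cc1O[C@H]1CCOC1`: 910 nM
compound 3 `COc1cc2ncnc(Nc3ccc(F)c(Cl)c3)c2cc1NC(=O)N/N=C/c1ccc(O)c(Br)c1`: "not active" (no number reported)

Compound 4 `COc1cc2ncnc(Nc3ccc(F)c(Cl)c3)c2cc1NC(=O)N/N=C/c1cc(Br)c(O)c(Br)c1` is not yet measured. Compound 4 differs from compound 3 by bromo in place of hydrogen on an aromatic carbon The same kind of change separates compound 1 from compound 2: bromo in place of hydrogen on an aromatic carbon The two places are not identical: in compound 4 the entering bromo is also meta to a bromo group (1 heavy atom), which is absent around the place in compound 1. The difference between the core of compound 2 and the core of compound 3 is not broken down here. No number is available for compound 3. In this assay the step of a 3.0-fold higher number from compound 2 to compound 1 (0.47 log units; beyond the scatter) Because the related change gave a weaker number in a 3.0-fold higher number from compound 2 to compound 1 (0.47 log units; beyond the scatter) and compound 3 is itself reported as "not active" (no number reported), compound 4 is expected to come out at around 20000 nM, estimated between 5000 nM and 100000 nM, with a real chance that no number is reported at all.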

Compound 4, half-maximal inhibitory concentration: 30200 nM
Estimate against measurement, compound 4: 1.5-fold (0.18 log units) below, within the range that was stated.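

Within the data shown here, no step from compound 3 to compound 4 can be read in this assay: compound 3 is reported as "not active" without a number, while compound 4 gives 30200 nM. As far as these compounds go, what 3,5-dibromo-4-hydroxyphenyl does relative to 3-bromo-4-hydroxyphenyl on this core stays open. No evidence bears on this result.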